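Removing one methoxy group from compound 2

The source may report more compounds than this note shows. Statements on the series, on what has been measured and on what is new or still open speak of the compounds shown alone.

Compound 2 `COc1cc(-c2cc(/C=C/C(=O)c3ccc(N)cc3)[nH]n2)cc(OC)c1OC` is the anchor here. In a functional assay on SK-OV-3 cells (Homo sapiens) for inhibition, read by sulforhodamine B assay, with a stated time of 48 h (on this read-out higher numbers stand for weaker inhibition of growth and lower numbers for stronger inhibition of growth), compound 2 gives 8320 nM, the lowest of the three numbers measured. Compound 1 `COc1ccc(-c2cc(/C=C/C(=O)c3ccc(N)cc3)[nH]n2)cc1` carries a single methoxy group on the same ring and in this assay compound 1 gives 18000 nM. Compound 3 `COc1cc(-c2cc(/C=C/C(=O)c3ccc(F)c(F)c3)[nH]n2)cc(OC)c1OC` keeps the three methoxy groups of compound 2 but changes the other end of the molecule, and in this assay compound 3 gives 58600 nM; that change, a 7.0-fold higher number from compound 2 to compound 3 (0.85 log units; beyond the scatter), weakened growth inhibition.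

Compound 4 `COc1ccc(-c2cc(/C=C/C(=O)c3ccc(N)cc3)[nH]n2)cc1OC` differs from compound 2 at the methoxy-bearing ring: hydrogen in place of methoxy on an aromatic carbon. Among the compounds with values here, no measured step covers exactly this change. The step from compound 2 to compound 3 sits on the carbonyl end and does not bear on it. The values of compound 1 and compound 2 show that stripping the ring down to a single methoxy group raised the number, so compound 4, which keeps two methoxy groups, is expected to land between them. The step from compound 2 to compound 4 is estimated at a 1.4-fold higher number from compound 2 to compound 4 (0.16 log units; within the scatter), a small weakening. Compound 4 is expected to give about 12000 nM in this assay, with a likely range from 6000 nM to 25000 nM.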

Compound 4, concentration for total growth inhibition: 16800 nM
Compound 4: middle estimate off by 1.4-fold (0.15 log units), on the low side; the range from low to high includes it.
By their numbers in this assay, from the lowest: compound 2; then compounds 4 and 1 (each within the scatter of the next); then compound 3.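

In this assay, replacing the methoxy group of compound 2 with hydrogen gives a 2.0-fold higher number from compound 2 to compound 4 (0.31 log units; beyond the scatter), so this methoxy group, ortho to a methoxy group and meta to another, makes a modest but readable difference to growth inhibition. The other single-methoxy step in the set behaves differently: methoxy in place of hydrogen on an aromatic carbon gives a 1.1-fold lower number from compound 1 to compound 4 (0.03 log units; within the scatter), so compounds 1 and 4 cannot be told apart in this assay, and among these three compounds a methoxy change does not register equally at each ring carbon. No measurement shown here explains why one methoxy step can be read and the other cannot.

As far as these compounds go, it remains open whether another group at the position that separates compound 2 from compound 4, such as a hydroxyl, an ethoxy group or a fluorine atom, would match methoxy or hydrogen. From the compounds shown here alone, it is also open whether this step keeps its size when the 3,4-difluorophenyl group of compound 3 replaces the 4-aminophenyl group on the carbonyl carbon.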